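The compounds below may be only part of what the source reports. "The series", "measured", "known", "first", "only" and "open" are said of these compounds alone.

Going by the values given here, in a functional assay (aorta) with Oryctolagus cuniculus as the target (on this read-out lower numbers stand for tighter binding and higher numbers for weaker binding), compound 1 (`NC(=O)c1ccc(OCCCN2CCC(C(c3ccc(F)cc3)c3ccc(F)cc3)CC2)cc1`) gives 31.6 nM and compound 2 (`Fc1ccc(C(c2ccc(F)cc2)C2CCN(CCCOc3ccc4ccccc4c3)CC2)cc1`) gives 7.94 nM as the lower of the two numbers measured so far. The next structure, compound 3 (`Fc1ccc(C(c2ccc(F)cc2)C2CCN(CCCCc3ccccc3)CC2)cc1`), has benzyl in place of (naphthalen-2-yl)oxy on a saturated chain carbon, three bonds along the chain from an amine nitrogen in a ring. Among the compounds with values here, only one measured step bears on this change: a 4.0-fold lower number from compound 1 to compound 2 (0.60 log units; beyond the scatter) with naphthalen-2-yl in place of 4-carbamoylphenyl. That modest step gives a rough scale, and it hints at a direction, since compound 3 has one aromatic ring as compound 1 does. Within the data shown here, it is weak guidance, as no measured pair shows what losing the oxygen does. The expected change is a modest rise, estimated as a 2.5-fold higher number from compound 2 to compound 3 (0.40 log units; beyond the scatter) in this assay with a wide margin. The estimate for compound 3 is 20 nM (expected range 6 nM to 60 nM).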

Compound 3, dissociation constant: 2.51 nM
Beside the measured number, compound 3's estimate is 8.0-fold (0.90 log units) above it; the measured number lies below the stated range.
By their numbers in this assay, from the lowest: compound 3; then compound 2; then compound 1.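

At this place, on a saturated chain carbon, three bonds along the chain from an amine nitrogen in a ring, the group with a single aromatic ring and no oxygen does better in this assay than the larger (naphthalen-2-yl)oxy, with a 3.2-fold lower number from compound 2 to compound 3 (0.50 log units; beyond the scatter) on swapping it for benzyl. The step from compound 1 to compound 2 alone could have suggested that a second aromatic ring helps here, but compound 3 shows that such a ring is not needed for a low number. Compound 1 and compound 3 each carry one aromatic ring, yet the change shows a 13-fold lower number from compound 1 to compound 3 (1.10 log units; beyond the scatter) in favour of benzyl, so the count of aromatic rings does not settle the number in these three compounds, and nothing measured gives a reason for these steps.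

In the compounds shown, the loss of the oxygen always comes together with a change in the ring part, so plain phenoxy at this place would be needed to tell the two apart. From the compounds shown here alone, whether the same benzyl keeps its low number on a longer chain also remains open.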